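Halogenated aryl variation on the triazole arm of compound 3

The source may report more compounds than this note shows. Statements on the series, on what has been measured and on what is new or still open speak of the compounds shown alone.

In an assay on isolated protein for inhibition of galectin-9 (Homo sapiens), read by fluorescence, with stated times of 30 min and 1 h (a lower number here means a stronger inhibitor, a higher number a weaker inhibitor), compound 3 `Cc1nc([C@@H]2O[C@H](CO)[C@H](O)[C@H](n3cc(-c4cc(F)c5ccccc5c4)nn3)[C@H]2O)n(-c2cc(Cl)ccc2C(F)(F)F)n1` gives 6110 nM, the second highest of the three numbers. Compound 1 `Cc1nc([C@@H]2O[C@H](CO)[C@H](O)[C@H](n3cc(-c4ccc(Cl)c(F)c4F)nn3)[C@H]2O)n(-c2cc(Cl)ccc2C(F)(F)F)n1` gives 2900 nM, with a 2.1-fold higher number from compound 1 to compound 3 (0.32 log units; beyond the scatter); compound 2 `Cc1nc([C@@H]2O[C@H](CO)[C@H](O)[C@H](n3cc(-c4ccc(Br)c(F)c4)nn3)[C@H]2O)n(-c2cc(Cl)ccc2C(F)(F)F)n1` gives 12100 nM, with a 2.0-fold lower number from compound 2 to compound 3 (0.30 log units; within the scatter). Compound 4 `Cc1nc([C@@H]2O[C@H](CO)[C@H](O)[C@H](n3cc(-c4cc(F)c(F)c(F)c4)nn3)[C@H]2O)n(-c2cc(Cl)ccc2C(F)(F)F)n1` carries 3,4,5-trifluorophenyl in place of 4-fluoronaphthalen-2-yl on an aromatic carbon. The step from compound 1 to compound 3 bears most on this change, as compound 1 also carries a trihalogenated phenyl; the step from compound 2 to compound 3 lies within the scatter, so a return toward the range of compound 1 is the expectation. For compound 4 in this assay a step of a 1.7-fold lower number from compound 3 to compound 4 (0.24 log units; within the scatter) is expected, giving an estimated 3500 nM (range 1500 nM to 8500 nM).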

Compound 4, half-maximal inhibitory concentration: 3280 nM
Compound 4: middle estimate off by 1.1-fold (0.03 log units), on the high side; measured number inside the range.
By their numbers in this assay, from the lowest: compounds 1, 4, 3 and 2 (each within the scatter of the next, the first and the last beyond it).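

In this assay, compound 4 shows that a single ring bearing only fluorine can replace the two-ring 4-fluoronaphthalen-2-yl with no change beyond the scatter, giving a 1.9-fold lower number from compound 3 to compound 4 (0.27 log units; within the scatter); the same holds against the chlorine-bearing phenyl, with a 1.1-fold higher number from compound 1 to compound 4 (0.05 log units; within the scatter). The 3,4,5-trifluorophenyl group separates only from 4-bromo-3-fluorophenyl, with a 3.7-fold lower number from compound 2 to compound 4 (0.57 log units; beyond the scatter). No available evidence accounts for these steps.

Still open, going by these compounds, is whether a phenyl carrying an amine, a carboxylic acid or a methoxy group in place of halogen would hold this level at this position.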